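The compounds below may be only part of what the source reports. "The series", "measured", "known", "first", "only" and "open" are said of these compounds alone.

In an ADME assay on BaF3 cells (Mus musculus) for antiproliferative activity, read by CCK-8 assay, with a stated time of 72 h (on this read-out higher numbers stand for weaker inhibition of growth and lower numbers for stronger inhibition of growth), compound 1 `CNC(=O)CCSc1ccc2c(/C=C/c3ccccn3)n[nH]c2c1` reads > 10000 nM, which is a limit of the assay. Compound 2 `O=C(CCSc1ccc2c(/C=C/c3ccccn3)n[nH]c2c1)Nc1ccccc1` gives 690 nM, and compound 3 `O=C(CCSc1ccc2c(/C=C/c3ccccn3)n[nH]c2c1)Nc1cccc(C(F)(F)F)c1` gives 2300 nM, the higher of the two actual numbers. Phenyl in place of methyl gave an at least 14-fold lower number from compound 1 to compound 2 (1.16 log units; beyond the scatter), and 3-(trifluoromethyl)phenyl gave an at least 4.3-fold lower number from compound 1 to compound 3 (0.63 log units; beyond the scatter). Compound 4 `CN(C)c1cccc(NC(=O)CCSc2ccc3c(/C=C/c4ccccn4)n[nH]c3c2)c1` carries dimethylamino in place of trifluoromethyl on an aromatic carbon, meta to a large group (dimethylamino in place of trifluoromethyl on an aromatic carbon). For the measured compounds named here, the closest evidence is the modest cost of adding trifluoromethyl, a 3.3-fold higher number from compound 2 to compound 3 (0.52 log units; beyond the scatter), but no measured compound carries dimethylamino. Losing trifluoromethyl should therefore recover part of that modest step, and the expected change is a 1.9-fold lower number from compound 3 to compound 4 (0.28 log units; within the scatter). For compound 4 the estimated value is 1200 nM, with an expected range of 400 nM to 4000 nM.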

Compound 4, concentration for 50% growth inhibition: > 10000 nM
Compound 4 ended at the assay's limit; the forecaster's own chance of this, stated with the estimate: 8%; middle value at least 8.3-fold (0.92 log units) from the limit.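

At this position, on an aromatic carbon meta to a large group, a substituent can cost far more than trifluoromethyl did: in this assay, dimethylamino in place of trifluoromethyl gave an at least 4.3-fold higher number from compound 3 to compound 4 (0.63 log units; beyond the scatter). Set against the unsubstituted phenyl, dimethylamino in place of hydrogen gave an at least 14-fold higher number from compound 2 to compound 4 (1.16 log units; beyond the scatter), the larger loss of the two substituents shown here. Compound 1 and compound 4 both sit at a limit, and the step between them cannot be read: the limit of > 10000 nM in this assay, at which 2 of the 4 values shown sit.

As far as these compounds go, whether a methoxy group or a primary amine at this position would fare like dimethylamino stays open. Also open, from the compounds shown here alone, is how dimethylamino would read on another carbon of the phenyl ring.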